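A few compounds are considered here, and "the series" means these few. Any claim that something is new, unique, unknown or untested is made for them only; others in the source may bear on it.

Compound 3 `COc1cc(-c2nnc3n2NC(c2ccco2)C(C(=O)c2cccc4ccccc24)S3)cc(OC)c1OC` stands where the numbers stop. In a functional assay on A549 cells (Homo sapiens) for cytotoxicity, read by MTT assay, with a stated time of 48 h (a higher number here means a weaker inhibitor, a lower number a stronger inhibitor), compound 3 reaches only a limit, > 100000 nM. Compound 1 `COc1cc(-c2nnc3n2NC(c2ccco2)C(C(=O)C2CC2)S3)cc(OC)c1OC` also sits at a limit in this assay, > 100000 nM, which is the limit of > 100000 nM in this assay, at which 2 of the 3 values shown sit. Compound 2 `COc1cc(-c2nnc3n2NC(c2ccco2)C(C(=O)c2ccccc2)S3)cc(OC)c1OC` alone gives a number in this assay, 33400 nM. Across the measured steps, an at least 2.9-fold lower number from compound 1 to compound 2 (0.47 log units; beyond the scatter), an at least 2.9-fold higher number from compound 2 to compound 3 (0.47 log units; beyond the scatter), while a step that the two limits leave unreadable from compound 1 to compound 3. Compound 4 `COc1cc(-c2nnc3n2NC(c2ccco2)C(C(=O)c2ccco2)S3)cc(OC)c1OC` differs from compound 3 in one place: furan-2-yl in place of naphthalen-1-yl on a carbonyl carbon. The step that bears on this is the one from phenyl to naphthalen-1-yl, and furan-2-yl now replaces that larger group, so because of an at least 2.9-fold higher number from compound 2 to compound 3 (0.47 log units; beyond the scatter) a lower number is expected for compound 4, a step of about an at least 2.5-fold lower number from compound 3 to compound 4 (0.39 log units; beyond the scatter). Compound 4 is estimated at 40000 nM, between 15000 nM and 120000 nM.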

Compound 4, half-maximal inhibitory concentration: 68700 nM
Estimate against measurement, compound 4: 1.7-fold (0.23 log units) below; the measured number falls inside the stated range.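

In this assay, furan-2-yl gives a second readable number at this carbonyl carbon, and a 2.1-fold higher number from compound 2 to compound 4 (0.31 log units; beyond the scatter) shows that even two aromatic rings of similar size can be told apart here. This is a single comparison, so it sets no order beyond compound 2 and compound 4. The other steps, an at least 1.4-fold lower number from compound 3 to compound 4 (0.16 log units; that floor lies within the scatter) and an at least 1.4-fold lower number from compound 1 to compound 4 (0.16 log units; that floor lies within the scatter), give only floors within the scatter and place compound 4 against neither compound, as both rest on an assay limit: the limit of > 100000 nM in this assay, at which 2 of the 4 values shown sit.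

As far as these compounds go, it remains open whether thiophen-2-yl or pyridin-2-yl on this carbonyl carbon would follow phenyl or furan-2-yl.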